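Moving the nitrile around the benzyloxy ring

This account rests on a few compounds, and the source may have more. Where it says the series, first, only, none or still open, it means among the compounds named here.

Measured so far:
- Compound 1, `FC(F)(F)c1ccc(CN2CCN(Cc3cc(-c4ccc(OCc5ccccc5)cc4)on3)CC2)cc1`, in a functional assay on Mahlavu cells (Homo sapiens) for antiproliferative activity, read by sulforhodamine B assay, with a stated time of 72 h (a higher number here means a weaker inhibitor, a lower number a stronger inhibitor), gives 11700 nM.
- Compound 2, `N#Cc1ccccc1COc1ccc(-c2cc(CN3CCN(Cc4ccc(C(F)(F)F)cc4)CC3)no2)cc1`, in this assay gives 3500 nM.
- Compound 3, `N#Cc1cccc(COc2ccc(-c3cc(CN4CCN(Cc5ccc(C(F)(F)F)cc5)CC4)no3)cc2)c1`, in this assay gives 10600 nM.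

Compound 3 stands second highest of these three numbers. Its nearest neighbour is compound 1, and the two values sit within the scatter of each other, as the step of a 1.1-fold lower number from compound 1 to compound 3 (0.04 log units; within the scatter) shows. Its furthest neighbour is compound 2, from which it is separated by a step beyond the scatter, a 3.0-fold higher number from compound 2 to compound 3 (0.48 log units; beyond the scatter).

Compound 4, `N#Cc1ccc(COc2ccc(-c3cc(CN4CCN(Cc5ccc(C(F)(F)F)cc5)CC4)no3)cc2)cc1`, differs from compound 3 in one place: 4-cyanophenyl in place of 3-cyanophenyl on a saturated chain carbon bound to an oxygen on an aromatic ring. Going by the values given here, no measured step shows this exact change. The step that bears on it most is a 3.0-fold higher number from compound 2 to compound 3 (0.48 log units; beyond the scatter), a move of the same nitrile to another spot on the same ring, which shifted the number by a modest amount. The step of a 3.3-fold lower number from compound 1 to compound 2 (0.52 log units; beyond the scatter) shows that adding a nitrile can help modestly, while a 1.1-fold lower number from compound 1 to compound 3 (0.04 log units; within the scatter) shows it can also do nothing beyond the scatter. Compound 4 is therefore expected to land somewhere between these outcomes, with a step of a 1.3-fold lower number from compound 3 to compound 4 (0.12 log units; within the scatter) that may well stay within the scatter. The estimate for compound 4 in this assay is 8000 nM, with a range from 3000 nM to 20000 nM.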

Compound 4, half-maximal inhibitory concentration: 4300 nM
Beside the measured number, compound 4's estimate is 1.9-fold (0.27 log units) above it; measured number inside the range.
By their numbers in this assay, from the lowest: compounds 2 and 4 (each within the scatter of the next); then compounds 3 and 1 (each within the scatter of the next).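

In this assay the place of the nitrile on the benzyl ring now reads more clearly: a 2.5-fold lower number from compound 3 to compound 4 (0.39 log units; beyond the scatter) sets 4-cyanophenyl apart from 3-cyanophenyl, while a 1.2-fold higher number from compound 2 to compound 4 (0.09 log units; within the scatter) leaves it level with 2-cyanophenyl. Against the unsubstituted benzyl group of compound 1, a 2.7-fold lower number from compound 1 to compound 4 (0.43 log units; beyond the scatter) is a second gain from adding a nitrile, so two of the three nitrile compounds show a gain, and compound 3 is the one that goes against this. Nothing measured here explains why the 3-cyanophenyl group stands apart from the other two.

Still open, going by these compounds, is whether the nitrile itself is needed, or whether a primary amide or a carboxylic acid in its place would give similar numbers. A second nitrile on the same ring is equally untested among the compounds shown.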